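The source may report more compounds than this note shows. Statements on the series, on what has been measured and on what is new or still open speak of the compounds shown alone.

Compound 1, `CNC(=O)c1cc(C(=O)NC2CC2)cn(Cc2nccc3[nH]ccc23)c1=O`: in a physicochemical assay for solubility (a lower number here means a less soluble compound, a higher number a more soluble compound), compound 1 gives 73 ug/mL.
Compound 2, `CNC(=O)c1cc(C(=O)NC2CC2)cn(Cc2ccc(F)cc2)c1=O`: in this assay compound 2 reaches only a limit of the assay, >= 162 ug/mL, not a number.
Compound 3, `CNC(=O)c1cc(C(=O)NC2CC2)cn(Cc2ccc(C)cc2)c1=O`: in this assay compound 3 gives 24 ug/mL.

Among the two actual numbers, compound 3 sits lowest; the nearest is compound 1, with a 3.0-fold lower number from compound 1 to compound 3 (0.48 log units; beyond the scatter), and compound 2 is known only as a limit (the limit of >= 162 ug/mL in this assay, at which 1 of the 3 values shown sits). Compound 4, `CNC(=O)c1cc(C(=O)NC2CC2)cn(Cc2ccccc2F)c1=O`, is not yet measured in this assay. It differs from compound 3 in one place: 2-fluorophenyl in place of 4-methylphenyl on a saturated chain carbon bound to an aromatic nitrogen.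

Going by the values given here, two measured steps bear on this. The closest is the one in the other direction, methyl in place of fluoro on an aromatic carbon, which gave an at least 6.7-fold lower number from compound 2 to compound 3 (0.82 log units; beyond the scatter). The replacement of the bicyclic group by a fluorophenyl gave an at least 2.2-fold higher number from compound 1 to compound 2 (0.34 log units; beyond the scatter), while the methylphenyl gave a 3.0-fold lower number from compound 1 to compound 3 (0.48 log units; beyond the scatter). Taken together, fluoro in place of methyl on the phenyl has so far gone with a higher number, so for compound 4 a rise beyond the scatter is expected in this assay, though the fluorine now sits at a different position of the ring and no measured pair tests that. Compound 4 is estimated at 110 ug/mL, between 45 ug/mL and 250 ug/mL, an expected step of a 4.6-fold higher number from compound 3 to compound 4 (0.66 log units; beyond the scatter).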

Compound 4, solubility: >= 145 ug/mL
Compound 4: a limit, no number; the forecaster's own chance of this, stated with the estimate: 30%; middle value at least 1.3-fold (0.11 log units) away from the limit.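

In this assay, 2-fluorophenyl in place of 4-methylphenyl on a saturated chain carbon bound to an aromatic nitrogen gave an at least 6.0-fold higher number from compound 3 to compound 4 (0.78 log units; beyond the scatter), so the rise seen earlier with 4-fluorophenyl is not confined to that one fluorophenyl group. Against the bicyclic group of compound 1, the result is less clear, with an at least 1.9-fold higher number from compound 1 to compound 4 (0.29 log units; that floor lies within the scatter), so compound 4 cannot yet be said to stand apart from compound 1 in the way compound 2 does. Compound 4, like compound 2, ends at a limit of the assay, so the step between these two fluorophenyl compounds cannot be read, and nothing separates the two placings of the fluorine: the limit of >= 145 ug/mL in this assay, at which 1 of the 4 values shown sits.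

What the compounds shown leave open is whether the step from compound 3 follows from the fluorine entering or from the methyl leaving, a question that an unsubstituted phenyl would bear on directly. On these data alone, how a chlorine or a methoxy group on the same ring, or an amine on the benzyl group, would read in this assay also remains open.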